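Swapping a five-membered ring on the side chain

The compounds below may be only part of what the source reports. "The series", "measured", "known", "first", "only" and "open" are said of these compounds alone.

Compound 2 `CC(C)C(c1ncco1)c1ccc(-c2ccc3cccc(F)c3c2)[nH]c1=O` is the starting point here. Among the compounds with values here, in a functional assay on CHO cells for antagonist activity at prostaglandin E2 receptor EP3 subtype (Homo sapiens), read by cAMP accumulation (on this read-out lower numbers stand for stronger inhibition and higher numbers for weaker inhibition), compound 2 gives 64 nM, the lowest of the two numbers measured so far, with compound 1 closest at 76 nM, a gap that lies within the scatter. Compound 1 `CC(C)C(Cc1ncc[nH]1)c1ccc(-c2ccc3cccc(F)c3c2)[nH]c1=O` carries the same core and differs only in the group on the saturated chain carbon: the step of a 1.2-fold lower number from compound 1 to compound 2 (0.07 log units; within the scatter) shows that replacing the (1H-imidazol-2-yl)methyl group by 1,3-oxazol-2-yl changed little.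

Compound 3 `CC(C)C(Cc1nnc[nH]1)c1ccc(-c2ccc3cccc(F)c3c2)[nH]c1=O` now moves in a related direction: (4H-1,2,4-triazol-3-yl)methyl in place of 1,3-oxazol-2-yl on a saturated chain carbon bound to an aromatic carbon and a saturated chain carbon. Within the data shown here, the incoming group resembles the one in compound 1, a five-membered ring attached through a methylene and bearing one hydrogen-bond donor. Among the measured compounds shown here, only one measured step bears on this change, and it stayed within the scatter, so a similar outcome is the most reasonable expectation. The expected step of a 1.1-fold higher number from compound 2 to compound 3 (0.04 log units; within the scatter) is none beyond the scatter. Compound 3 is accordingly estimated to give 70 nM, with a likely range from 30 nM to 170 nM.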

Compound 3, half-maximal inhibitory concentration: 17 nM
Compound 3: middle estimate off by 4.1-fold (0.61 log units), on the high side; measured number outside the range, below it.
By their numbers in this assay, from the lowest: compound 3; then compounds 2 and 1 (each within the scatter of the next).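

Within the data shown here, the ring on this saturated chain carbon does matter in this assay, even though the first swap at this position stayed within the scatter. With the methylene link kept, 4H-1,2,4-triazol-3-yl in place of 1H-imidazol-2-yl gives a 4.5-fold lower number from compound 1 to compound 3 (0.65 log units; beyond the scatter), so a methylene-linked five-membered ring with a hydrogen-bond donor, which compound 1 also has, is not enough on its own to reach the lower number, and the identity of the ring counts. The step of a 3.8-fold lower number from compound 2 to compound 3 (0.58 log units; beyond the scatter) is of similar size, but it changes the ring and the link together, and nothing shown gives a reason for either step.

As far as these compounds go, it remains open how much of that step belongs to the methylene link alone, which a (1,3-oxazol-2-yl)methyl group or a directly attached 4H-1,2,4-triazol-3-yl group would help to settle. Also open, from the compounds shown here alone, is whether a tetrazol-5-ylmethyl group, with one more ring nitrogen, or a carboxylic acid on the same chain carbon would lower the number further or raise it.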